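Acetyl to nitrile at the aromatic carbon of compound 3

A few compounds are considered here, and "the series" means these few. Any claim that something is new, unique, unknown or untested is made for them only; others in the source may bear on it.

Of the compounds shown here, three of one series have been measured in an assay on membranes from brain for displacement of a labelled ligand from Neuronal acetylcholine receptor; alpha4/beta2 (Rattus norvegicus), with a stated time of 3 h; on this read-out lower numbers stand for stronger inhibition and higher numbers for weaker inhibition. Compound 1 `Cc1cc(/C=C2\CCCN=C2c2cccnc2)cc(C)c1O` gives 360 nM, compound 2 `CCN(CC)c1ccc(/C=C2\CCCN=C2c2cccnc2)c(O)c1` gives 130 nM, and compound 3 `CC(=O)c1ccc(/C=C2\CCCN=C2c2cccnc2)cc1` gives 4490 nM. Compound 3 therefore stands at the highest number of the three, and its gaps to compound 1 and to compound 2 both lie beyond the scatter, so it is the weakest binder so far.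

Compound 4 `N#Cc1ccc(/C=C2\CCCN=C2c2cccnc2)cc1` is not yet measured. It differs from compound 3 in one place: cyano in place of acetyl on an aromatic carbon. For the measured compounds named here, both groups carry one acceptor and no donor; on the data at hand no step of this kind has been measured, so a small step is expected, with a 1.5-fold lower number from compound 3 to compound 4 (0.18 log units; within the scatter) probably within the scatter, perhaps leaning toward a lower number. Compound 4 is therefore estimated at 3000 nM, in a range from 1000 nM to 9000 nM.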

Compound 4, inhibition constant: 1230 nM
Beside the measured number, compound 4's estimate is 2.4-fold (0.39 log units) above it; measured number inside the range.
By their numbers in this assay, from the lowest: compound 2; then compound 1; then compound 4; then compound 3.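

In this assay this position, on an aromatic carbon para to a large group, responds to a change of group: cyano in place of acetyl gives a 3.7-fold lower number from compound 3 to compound 4 (0.56 log units; beyond the scatter) even though the hydrogen-bond donor and acceptor counts stay the same. For the compounds shown here, this is the first step that can be read at a single place. Nothing at hand accounts for its size.

As far as these compounds go, whether an amine, a carboxylic acid or a methoxy group at this aromatic carbon would give a lower or a higher number remains open. So does whether the step from acetyl to cyano carries over to cores bearing a hydroxyl group.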